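The source may report more compounds than this note shows. Statements on the series, on what has been measured and on what is new or still open speak of the compounds shown alone.

In a physicochemical assay for solubility, with a stated time of 18 h, at pH 7.4 (on this read-out lower numbers stand for lower solubility and higher numbers for higher solubility), three compounds built on a shared core have been measured. Compound 1 `c1ccc(Oc2ccc3c(NCCCNCc4ccco4)ccnc3c2)cc1` gives 14500 nM. Compound 2 `Cc1cc(C)cc(Cc2ccc3c(NCCCNCc4ccco4)ccnc3c2)c1` gives 4200 nM, and compound 3 `c1coc(CNCCCNc2ccnc3cc(C4CCCCC4)ccc23)c1` gives 4200 nM. Compound 3 therefore stands level with compound 2 at the digits shown, the two together giving the lowest numbers of the three, while compound 1 sits apart: the step of a 3.5-fold lower number from compound 1 to compound 3 (0.54 log units; beyond the scatter) is modest but beyond the scatter, and so is a 3.5-fold lower number from compound 1 to compound 2 (0.54 log units; beyond the scatter). By contrast, no change at the digits printed from compound 2 to compound 3 (within the scatter).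

Compound 4 `CCC(CC)c1ccc2c(NCCCNCc3ccco3)ccnc2c1` differs from compound 3 in a single place: pentan-3-yl in place of cyclohexyl on an aromatic carbon. Among the compounds with values here, no measured step exchanges cyclohexyl for pentan-3-yl, so nothing bears on it directly. Within the data shown here, the nearest precedent is no change at the digits printed from compound 2 to compound 3 (within the scatter), where one carbon-only group gave way to another without any shift in this assay, whereas the two steps that did move the number both replaced phenoxy, a group absent from compound 4. On that basis a step of no change beyond the scatter is expected from compound 3 to compound 4, that is a 1.1-fold higher number from compound 3 to compound 4 (0.03 log units; within the scatter). Compound 4 is accordingly estimated at 4500 nM, within a range from 2000 nM to 12000 nM.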

Compound 4, solubility: 4200 nM
Compound 4: the middle estimate sits 1.1-fold (0.03 log units) above what was measured; the measured number falls inside the stated range.
By their numbers in this assay, from the lowest: compounds 2, 3 and 4 (each within the scatter of the next); then compound 1.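

In this assay, pentan-3-yl, with no ring and 5 heavy atoms, takes the place of cyclohexyl, with its six-membered ring and 6 heavy atoms, and the result is small (no change at the digits printed from compound 3 to compound 4 (within the scatter)), so a ring of carbon only is not required at this aromatic carbon to hold the number at this level. The comparison with the benzyl-type group reads the same way (no change at the digits printed from compound 2 to compound 4 (within the scatter)), which puts three carbon-only groups of quite different shape level with one another, while compound 1 stays apart, as the phenoxy group again gives the higher number (a 3.5-fold lower number from compound 1 to compound 4 (0.54 log units; beyond the scatter)). Nothing measured here explains why these three groups read alike or why compound 1 stands apart.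

The compounds shown leave open whether the separation of compound 1 follows the oxygen that links its phenyl ring, which an unsubstituted phenyl or a methoxy group at the same carbon could begin to test. They also leave open whether a group of a different kind here, such as a dimethylamino group or a carboxylic acid, would move the number when the carbon-only groups do not.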